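The source may hold more compounds than are shown below. What is called first, only, known or untested is meant among the compounds shown, and "the series" means these compounds.

Working notes on the series, all read in a functional assay (muscle tissue) with Rattus norvegicus as the target; on this read-out lower numbers stand for an effect already at smaller amounts and higher numbers for an effect only at larger amounts of compound. On the shared core, compound 1 `CCNC(=O)C1=CC(C)(C)Oc2ccc([N+](=O)[O-])cc21` gives 4.57 nM, compound 2 `CCCNC(=O)C1=CC(C)(C)Oc2ccc([N+](=O)[O-])cc21` gives 5.75 nM and compound 3 `CC1(C)C=C(C(=O)NCCO)c2cc([N+](=O)[O-])ccc2O1` gives 182 nM. Compound 3 therefore holds the highest number of the three, clearly apart from both others.

Compound 4 `CC1(C)C=C(C(=O)NCCC#N)c2cc([N+](=O)[O-])ccc2O1` differs from compound 3 by one change: cyano in place of hydroxy on a saturated chain carbon, two bonds along the chain from an amide-type nitrogen. In words, this is cyano in place of hydroxy on a saturated chain carbon, two bonds along the chain from an amide-type nitrogen.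

Among the compounds with values here, three measured steps bear on this place. The step of a 1.3-fold higher number from compound 1 to compound 2 (0.10 log units; within the scatter) shows that methyl in place of hydrogen leaves the number within the scatter. The steps of a 40-fold higher number from compound 1 to compound 3 (1.60 log units; beyond the scatter) and a 32-fold higher number from compound 2 to compound 3 (1.50 log units; beyond the scatter) are both large, and each ends at the hydroxy compound. Cyano has not been measured at this place, so how much of that gap it closes is open. The expectation, resting on these two large steps, is a move to a lower number in this assay, beyond the scatter but smaller than either of them. The estimated step is a 6.1-fold lower number from compound 3 to compound 4 (0.78 log units; beyond the scatter). Compound 4 is expected at 30 nM, with an estimated range of 8 nM to 110 nM.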

Compound 4, half-maximal effective concentration: 2.82 nM
The estimate for compound 4 lay 11-fold (1.03 log units) above the measured number; the whole stated range lies above it.
By their numbers in this assay, from the lowest: compounds 4, 1 and 2 (each within the scatter of the next, the first and the last beyond it); then compound 3.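

In this assay, cyano in place of hydroxy on this chain carbon gives a 65-fold lower number from compound 3 to compound 4 (1.81 log units; beyond the scatter), so the high number of compound 3 is not shared by every group larger than hydrogen or methyl at this place; among the groups shown, only hydroxy stands apart. Against the shorter and longer alkyl amides the picture is tighter: cyano in place of methyl gives a 2.0-fold lower number from compound 2 to compound 4 (0.31 log units; beyond the scatter), a modest step, while cyano in place of hydrogen gives a 1.6-fold lower number from compound 1 to compound 4 (0.21 log units; within the scatter), which stays within the scatter, so this place accepts cyano without the loss seen with hydroxy. The change exchanges a group that counts a hydrogen-bond donor for one that counts none while the hydrogen-bond acceptor count stays the same, but nothing measured on these compounds gives a reason for the steps.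

Going by these compounds, whether the high number belongs to hydroxy alone, or also appears with an amine or a carboxylic acid on this chain carbon, stays open. Also open, on these data alone, is whether a methoxy group, which keeps the oxygen without its hydrogen, or a longer chain carrying the cyano group, would stay with compound 4 or move towards compound 3.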